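A few compounds are considered here, and "the series" means these few. Any claim that something is new, unique, unknown or untested is made for them only; others in the source may bear on it.

Measured in a functional assay on HT-29 cells (Homo sapiens) for inhibition, read by MTT assay, with a stated time of 48 h; a lower number here means a stronger inhibitor, a higher number a weaker inhibitor:
- compound 1 `CCSc1nnc(-c2cc(OC)c(OC)c(OC)c2)n1-c1ccc(OC)cc1`: > 60000 nM (a limit)
- compound 2 `COc1ccc(C(=O)CSc2nnc(-c3cc(OC)c(OC)c(OC)c3)n2-c2ccc(OC)cc2)cc1`: > 60000 nM (a limit)
- compound 3 `COc1ccc(-n2c(SCC(=O)C3CC3)nnc2-c2cc(OC)c(OC)c(OC)c2)cc1`: > 60000 nM (a limit)

Compound 3 stands at > 60000 nM, which is a limit. It shares that position with the rest of the set: the limit of > 60000 nM in this assay, at which 3 of the 3 values shown sit.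

The next compound is compound 4 `COc1ccc(NC(=O)CSc2nnc(-c3cc(OC)c(OC)c(OC)c3)n2-c2ccc(OC)cc2)cc1`, with (4-methoxyphenyl)amino in place of cyclopropyl on a carbonyl carbon.

The closest measured change, at the same carbonyl carbon, is a step that the two limits leave unreadable from compound 2 to compound 3. Two more bear on it at the saturated chain carbon bound to a sulfur: a step that the two limits leave unreadable from compound 1 to compound 2 and a step that the two limits leave unreadable from compound 1 to compound 3. For the measured compounds named here, none of these has a readable size, so the series offers no measured step to carry over.

The expectation leans on compound 2, which also carries a 4-methoxyphenyl group and gives > 60000 nM, a limit. The expected change is an at least 1.3-fold lower number from compound 3 to compound 4 (0.12 log units; that floor lies within the scatter), with nothing beyond the scatter and no firm direction expected.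

Compound 4 is estimated at 45000 nM, with an expected range from 12000 nM to 60000 nM.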

Compound 4, half-maximal inhibitory concentration: 45300 nM
Estimate against measurement, compound 4: 1.0-fold (0.00 log units) below, within the range that was stated.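

In this assay, (4-methoxyphenyl)amino on the carbonyl carbon gives compound 4 a number, 45300 nM, whereas the steps among compound 1, compound 2 and compound 3 cannot be read. The change now has a minimum size, and each floor lies within the scatter: an at least 1.3-fold lower number from compound 3 to compound 4 (0.12 log units; that floor lies within the scatter), an at least 1.3-fold lower number from compound 2 to compound 4 (0.12 log units; that floor lies within the scatter) and an at least 1.3-fold lower number from compound 1 to compound 4 (0.12 log units; that floor lies within the scatter). The series therefore gains a first number but no demonstrated gain in potency, and the rest of the set stays at a limit: the limit of > 60000 nM in this assay, at which 3 of the 4 values shown sit.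

As far as these compounds go, the true size of all three steps stays open, since each runs from a limit to a number. Also open, from the compounds shown here alone, is how a plain amino group, a dimethylamino group or a hydroxyl group on the same carbonyl carbon would read, which would test whether the amide hydrogen or the 4-methoxyphenyl ring matters.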